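This account rests on a few compounds, and the source may have more. Where it says the series, first, only, none or still open, it means among the compounds named here.

Of the compounds shown here, three that share one core have been measured in a functional assay on CHO cells for agonist activity at Free fatty acid receptor 1 (Homo sapiens), read by FLIPR and calcium flux; a higher number here means that more compound is needed for the effect, a lower number that less compound is needed. Compound 1 `O=C(O)COc1ccc(NCc2cccc(-c3ccccc3)c2)cc1F` gives 58.5 nM. Where compound 1 carries a hydrogen, compound 2 `O=C(O)COc1ccc(NCc2cccc(-c3ccccc3F)c2)cc1F` carries a fluoro and gives 36.5 nM. Compound 3 `O=C(O)COc1ccc(NCc2cccc(-c3ccccc3Cl)c2)cc1F`, which carries a chloro at that place, gives 19.3 nM. The step of a 3.0-fold lower number from compound 1 to compound 3 (0.48 log units; beyond the scatter) is beyond the scatter, whereas the step of a 1.9-fold lower number from compound 2 to compound 3 (0.28 log units; within the scatter) stays within it, so compound 3 is clearly separated only from compound 1. The step of a 1.6-fold lower number from compound 1 to compound 2 (0.20 log units; within the scatter) also stays within the scatter.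

Compound 4 `Cc1ccccc1-c1cccc(CNc2ccc(OCC(=O)O)c(F)c2)c1` differs from compound 3 in one place: methyl in place of chloro on an aromatic carbon. Among the measured compounds shown here, no measured step here exchanges a chloro for a methyl, so the expectation rests on the changes at that same position. The step of a 3.0-fold lower number from compound 1 to compound 3 (0.48 log units; beyond the scatter) shows that filling this position with a chloro rather than a hydrogen lowers the number modestly, and the step of a 1.9-fold lower number from compound 2 to compound 3 (0.28 log units; within the scatter) shows that changing one small group for another at this position moves the number only within the scatter. A methyl is, like the chloro, a single heavy atom at that position, so the expected step of a 1.5-fold higher number from compound 3 to compound 4 (0.16 log units; within the scatter) is small, most likely within the scatter. Compound 4 is therefore estimated at 28 nM, with a range from 12 nM to 65 nM.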

Compound 4, half-maximal effective concentration: 4.8 nM
Beside the measured number, compound 4's estimate is 5.8-fold (0.77 log units) above it; the measured number lies below the stated range.
By their numbers in this assay, from the lowest: compound 4; then compounds 3, 2 and 1 (each within the scatter of the next, the first and the last beyond it).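

Chloro and methyl count alike under the computed comparison, each a single heavy atom with no hydrogen-bond donors or acceptors and no net charge, yet exchanging one for the other on this aromatic carbon, ortho to a large group, is not a neutral swap in this assay: the change gives a 4.0-fold lower number from compound 3 to compound 4 (0.60 log units; beyond the scatter). Methyl also stands clear of the other two groups at this place, with a 7.6-fold lower number from compound 2 to compound 4 (0.88 log units; beyond the scatter) and a 12-fold lower number from compound 1 to compound 4 (1.09 log units; beyond the scatter), so this single position can move the number much further than the hydrogen, fluoro and chloro compounds alone showed. Nothing measured here accounts for the gap between methyl and chloro.

The compounds shown leave open whether a longer chain such as ethyl, or a group such as methoxy or trifluoromethyl, would lower the number further at this same place or raise it again. They also leave open whether a hydroxyl or an amine would be tolerated there, and whether the methyl would give a similar step on a core lacking the fluoro of the shared core.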